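Ether and ester side chains on the shared core

The source may report more compounds than this note shows. Statements on the series, on what has been measured and on what is new or still open speak of the compounds shown alone.

Measured compounds in a functional assay on the whole organism for inhibition, with Mus musculus as the target, at a dose of 10 mg/kg; a lower number here means less inhibition, a higher number more inhibition at the dose given (going by the name of the read-out):
compound 1 `CCOCC1=CS(=O)(=O)c2ccccc2C1=O`: 92.4%
compound 2 `CC(C)OCC1=CS(=O)(=O)c2ccccc2C1=O`: 99.2%
compound 3 `O=COCC1=CS(=O)(=O)c2ccccc2C1=O`: 91.6%

All three numbers sit within the scatter of one another. Compound 3 is separated from compound 1 by a number 0.8 percentage points lower from compound 1 to compound 3 (within the scatter) and from compound 2 by a number 7.6 percentage points lower from compound 2 to compound 3 (within the scatter); compound 1 and compound 2 are separated by a number 6.8 percentage points higher from compound 1 to compound 2 (within the scatter). Nothing in this set marks one compound off from the others.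

Compound 4 `CC(=O)OCC1=CS(=O)(=O)c2ccccc2C1=O` is not yet measured. Compound 3 to compound 4: methyl in place of hydrogen on a carbonyl carbon

Among the measured compounds shown here, the steps that bear on this change are the exchanges on the oxygen on a saturated carbon, formyl against ethyl and formyl against isopropyl, which gave a number 0.8 percentage points lower from compound 1 to compound 3 (within the scatter) and a number 7.6 percentage points lower from compound 2 to compound 3 (within the scatter), both within the scatter, as was the growth of ethyl to isopropyl with a number 6.8 percentage points higher from compound 1 to compound 2 (within the scatter). The exchange of hydrogen for methyl on the carbonyl carbon is a smaller alteration than any of these. The expected step in this assay is therefore a number 1.4 percentage points higher from compound 3 to compound 4 (within the scatter), none beyond the scatter in either direction. For compound 4 the estimated value is 93%, with a range from 84% to 100%.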

Compound 4, a percentage reported as inhibition, in the whole organism at one dose (the size of the read-out at that dose, not a potency): 99.5%
Beside the measured number, compound 4's estimate is 6.5 percentage points below it; low and high end bracket the measured number.
By their numbers in this assay, from the lowest: compounds 3, 1, 2 and 4 (each within the scatter of the next).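

In this assay methyl in place of hydrogen on a carbonyl carbon, the formyl to acetyl change, gives a number 7.9 percentage points higher from compound 3 to compound 4 (within the scatter) and so does not move the read-out beyond the scatter at this position. The acetyl ester also sits within the scatter of both ethers, with a number 0.3 percentage points higher from compound 2 to compound 4 (within the scatter) and with a number 7.1 percentage points higher from compound 1 to compound 4 (within the scatter) so that, among these four compounds, neither the ester or ether link on the oxygen on a saturated carbon nor the size of the group on it sets one compound apart. Nothing available offers a reason for how these numbers fall.

Going by these compounds, with a single dose, the read-out gives the size of the inhibition at that dose and not a potency, so whether these four compounds would separate at another dose stays open. Also open, on these data alone, is how the read-out responds when an amine, a carboxylic acid or a longer chain takes the place of the acetyl group on the same oxygen of the side chain.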